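Swapping Methyl for a Furan Ring in Compound 4

The source may hold more compounds than are shown below. What is called first, only, known or untested is meant among the compounds shown, and "the series" means these compounds.

Compound 2 `COc1ccc(Nc2cc(C)oc(=O)c2)cc1` stands apart among the three measured compounds. In a functional assay on KBVIN cells (Homo sapiens) for cytotoxicity, read by MTT assay, with a stated time of 72 h (a lower number here means that less compound is needed, a higher number that more compound is needed for the effect), compound 2 gives > 30 uM, which is a limit of the assay rather than a number (the limit of > 30 uM in this assay, at which 1 of the 3 values shown sits). The two other measured compounds carry a phenyl ring where compound 2 carries a methyl: compound 1 `COc1cccc(Nc2cc(-c3ccccc3)oc(=O)c2)c1` gives 0.55 uM in this assay, and compound 3 `COc1ccccc1Nc1cc(-c2ccccc2)oc(=O)c1` gives 0.49 uM. Compound 4 `COc1ccc(Nc2cc(-c3ccco3)oc(=O)c2)cc1` is not yet measured. It differs from compound 2 in one place: furan-2-yl in place of methyl on an aromatic carbon. No step between measured compounds is available for this change, so the expectation rests on compound 1 and compound 3, which carry an aromatic ring at this position and sit far from the limit shown by compound 2. The expected direction is therefore toward lower numbers, by a step well beyond the usual scatter. Compound 4 is estimated at 1.5 uM, within a range from 0.3 uM to 8 uM. The estimated step is an at least 20-fold lower number from compound 2 to compound 4 (1.30 log units; beyond the scatter).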

Compound 4, concentration for half-maximal effect: 1.46 uM
Compound 4: middle estimate off by 1.0-fold (0.01 log units), on the high side; the range from low to high includes it.
By their numbers in this assay, from the lowest: compounds 3 and 1 (each within the scatter of the next); then compound 4. At a limit, above all of these: compound 2.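

In this assay, furan-2-yl in place of methyl on an aromatic carbon, next to the ring oxygen, gives an at least 20-fold lower number from compound 2 to compound 4 (1.31 log units; beyond the scatter), with the rest of the structure unchanged. Within the data shown here, this is the first change at this position that can be read on its own, as the earlier compounds with an aromatic ring here also differ from compound 2 in a second place. The value of compound 2 is a limit of the assay and not a number, so the true size of the step stays unknown: the limit of > 30 uM in this assay, at which 1 of the 4 values shown sits.

The compounds shown leave open whether an aromatic ring is needed here or whether any larger group would serve, which a cyclohexyl ring or a longer chain such as n-butyl could separate. They also leave open what the furan oxygen contributes, a question that thiophen-2-yl at the same position could address.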